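Compound 2 to compound 3: methoxy in place of methyl

This account rests on a few compounds, and the source may have more. Where it says the series, first, only, none or still open, it means among the compounds named here.

- compound 1 `CC[C@]1(C(=O)O)CC[C@H](C(=O)N2CC[C@](c3ccc(C(F)(C(F)(F)F)C(F)(F)F)cc3)(S(=O)(=O)c3ccc(F)cc3)C2)CC1` gives 100% in an ADME assay on microsomes from liver (Homo sapiens) for metabolic stability, with a stated time of 10 min; a lower number here means that less of the compound is left, a higher number that more of the compound is left
- compound 2 `C[C@]1(C(=O)N2CC[C@](c3ccc(C(F)(C(F)(F)F)C(F)(F)F)cc3)(S(=O)(=O)c3ccc(F)cc3)C2)CC[C@H](C(=O)O)CC1` gives 80% in this assay

Of the two measured compounds, compound 2 stands lowest (80%), and the gap up to compound 1 lies beyond the scatter. Compound 3 `CO[C@]1(C(=O)N2CC[C@](c3ccc(C(F)(C(F)(F)F)C(F)(F)F)cc3)(S(=O)(=O)c3ccc(F)cc3)C2)CC[C@H](C(=O)O)CC1` differs from compound 2 by methoxy in place of methyl on a saturated ring carbon, which turns 4-carboxy-1-methylcyclohexyl into 4-carboxy-1-methoxycyclohexyl. The rest of the molecule stays the same.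

Among the compounds with values here, only one measured step bears on this change. The step of a number 20 percentage points lower from compound 1 to compound 2 (beyond the scatter) replaced 4-carboxy-4-ethylcyclohexyl with 4-carboxy-1-methylcyclohexyl. Within the data shown here, no measured compound carries methoxy, so this single modest step gives only a rough guide to size and none to direction. A smaller step is expected here, leaning slightly downward and probably staying within the scatter. The expected change is a number 5 percentage points lower from compound 2 to compound 3 (within the scatter) (an estimate with an uncertain sign). In this assay the value expected for compound 3 is 75% (estimated range 58% to 93%).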

Compound 3, percent of the compound remaining: 82%
Compound 3: the middle estimate sits 7 percentage points below what was measured; measured number inside the range.
By their numbers in this assay, from the lowest: compounds 2 and 3 (each within the scatter of the next); then compound 1.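

In this assay, methoxy in place of methyl on this saturated ring carbon gives a number 2 percentage points higher from compound 2 to compound 3 (within the scatter), so adding the oxygen and its hydrogen-bond acceptor to this place does not separate the two compounds in this read-out. The gap to the ethyl compound remains with the new group, with 4-carboxy-1-methoxycyclohexyl in place of 4-carboxy-4-ethylcyclohexyl giving a number 18 percentage points lower from compound 1 to compound 3 (beyond the scatter), and a number 20 percentage points lower from compound 1 to compound 2 (beyond the scatter) has the same direction, so compounds 2 and 3 both stand apart from compound 1 while no gap beyond the scatter separates them from each other. The data at hand offer no measurement that accounts for either step.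

Still open, going by these compounds, is whether other groups on this saturated ring carbon, such as ethoxy, hydroxy or fluorine, would also stay within the scatter of compound 2. Also open, on these data alone, is whether the gap to compound 1 belongs to the ethyl group itself or to where it stands on the ring, a question that 4-carboxy-1-ethylcyclohexyl on the same core would address.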